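A few compounds are considered here, and "the series" means these few. Any claim that something is new, unique, unknown or untested is made for them only; others in the source may bear on it.

Measured compounds:
compound 1 `CC(=O)Oc1ccccc1C(=O)O[C@H]1CO[C@H]2[C@@H]1OC[C@H]2OC(=O)c1ccccc1C` gives 0.0138 h in an ADME assay on a cell-free system (plasma, Homo sapiens) for metabolic stability, with Plasma (Rattus norvegicus) as the target, read by HPLC, at pH 7.4; on this read-out lower numbers stand for a shorter-lived compound and higher numbers for a longer-lived compound;
compound 2 `CC(=O)Oc1ccccc1C(=O)O[C@H]1CO[C@H]2[C@@H]1OC[C@H]2OC(=O)c1ccccc1OC(=O)c1ccccc1` gives 0.0722 h in this assay.

Compound 1 holds the lowest of the two numbers shown, and the nearest to it is compound 2. Among the measured compounds shown here, the single measured step, a 5.2-fold higher number from compound 1 to compound 2 (0.72 log units; beyond the scatter), exchanges methyl on an aromatic carbon for benzoyloxy, a change quite unlike the one that leads to compound 3 `CC(=O)Oc1ccccc1C(=O)O[C@H]1CO[C@H]2[C@@H]1OC[C@H]2OC(=O)c1cccnc1`. That change is pyridin-3-yl in place of 2-methylphenyl on a carbonyl carbon: the 2-methylphenyl group leaves and pyridin-3-yl enters, bringing one hydrogen-bond acceptor. For the measured compounds named here, no measured pair shows what a ring nitrogen, or the loss of the methyl, does here, so the expectation for compound 3 rests only on the small size of the change. Compound 3 is therefore expected to sit close to compound 1, with a step of a 1.2-fold lower number from compound 1 to compound 3 (0.06 log units; within the scatter) that stays within the scatter. The estimate for compound 3 is 0.012 h, ranging from 0.004 h to 0.04 h.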

Compound 3, half-life: 0.00617 h
Compound 3: the middle estimate sits 1.9-fold (0.29 log units) above what was measured; low and high end bracket the measured number.
By their numbers in this assay, from the lowest: compound 3; then compound 1; then compound 2.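

In this assay the exchange of 2-methylphenyl for pyridin-3-yl on a carbonyl carbon gives a 2.2-fold lower number from compound 1 to compound 3 (0.35 log units; beyond the scatter), so replacing the whole ring at this position moves the half-life beyond the scatter. Compound 3 now holds the lowest number of the three, and the two steps away from compound 1 run in opposite directions: the earlier one, a 5.2-fold higher number from compound 1 to compound 2 (0.72 log units; beyond the scatter), goes up, while this one goes down. Nothing at hand gives a reason for the shorter half-life of compound 3.

The compounds shown do not separate the entry of the ring nitrogen from the loss of the methyl, as both arrive in this single change. A plain phenyl on the same carbonyl carbon would divide the two, and pyridin-4-yl would show whether the place of the ring nitrogen matters.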